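A Nitrophenyl for a Furan: Expected Cytotoxicity of Compound 4

The source may hold more compounds than are shown below. What is called first, only, known or untested is meant among the compounds shown, and "the series" means these compounds.

Of the compounds shown here, three built on one shared core have been tested in an ADME assay on J774.A1 cells (Mus musculus) for cytotoxicity, read by MTT assay, with a stated time of 72 h; on this read-out higher numbers stand for lower toxicity in this test and lower numbers for higher toxicity in this test. Compound 1 `CC1(c2ccc(-c3ccco3)cc2)CC(S(=O)(=O)c2ccc(F)cc2)=C(c2ccc(/C(N)=N\O)cc2)O1` gives 4560 nM. Compound 2 `CCC1(c2ccccc2OC)CC(S(=O)(=O)c2ccc(F)cc2)=C(c2ccc(/C(N)=N\O)cc2)O1` gives 9880 nM, and compound 3 `CC1(Cc2ccccc2)CC(S(=O)(=O)c2c(F)cccc2F)=C(c2ccc(/C(N)=N\O)cc2)O1` gives 27000 nM. Among these three numbers compound 1 stands lowest, which in this test means the highest toxicity; its nearest neighbour is compound 2, whose number lies higher by a gap beyond the usual scatter, and compound 3 lies furthest away, also beyond the scatter. No two of the measured compounds differ in only one place, so no isolated structural step can be read from the measured set.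

Compound 4 `CC1(c2ccc(-c3cccc([N+](=O)[O-])c3)cc2)CC(S(=O)(=O)c2ccc(F)cc2)=C(c2ccc(/C(N)=N\O)cc2)O1` has not yet been measured in this assay. It differs from compound 1 in one place: 3-nitrophenyl in place of furan-2-yl on an aromatic carbon. The entering group sits on an aromatic carbon of a six-membered aromatic ring of carbon only, para to a large group.

Among the measured compounds shown here, with no measured step of this kind to lean on, the direction is uncertain, and the expected step is a 1.3-fold lower number from compound 1 to compound 4 (0.11 log units; within the scatter), modest next to the gaps among the measured compounds. Compound 4 is estimated at 3500 nM in this assay, with a range from 1200 nM to 10000 nM.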

Compound 4, half-maximal cytotoxic concentration: 11100 nM
Estimate against measurement, compound 4: 3.2-fold (0.50 log units) below, outside the stated range (above it).
By their numbers in this assay, from the lowest: compound 1; then compounds 2 and 4 (each within the scatter of the next); then compound 3.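

In this assay, among the compounds shown here, the replacement of furan-2-yl by 3-nitrophenyl gives the first change in the set that can be read on its own: a 2.4-fold higher number from compound 1 to compound 4 (0.39 log units; beyond the scatter). This shows that the group on this aromatic carbon, para to a large group, matters in this test, since changing it alone moves the number beyond the scatter, in the direction of lower toxicity. The exchange swaps a five-membered aromatic ring with 1 hetero atom for a six-membered aromatic ring of carbon only that carries a nitro group, but no measurement shown ties the step to any property of either group.

The compounds shown do not separate the contribution of the new ring from that of its nitro group, and a plain phenyl on the same carbon would be the direct test of that. On these data alone, it also stays open whether an amine or a carboxylic acid in place of the nitro group would move the number the same way, or whether the step would hold with the other groups carried by compounds 2 and 3 on the shared core.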